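Dropping the fluoro from compound 3

This account rests on a few compounds, and the source may have more. Where it says the series, first, only, none or still open, it means among the compounds named here.

Measured compounds:
compound 1 `Cc1ccc2ncc(S(=O)(=O)c3ccc(C)c(Cl)c3)c(N3CCC(C)CC3)c2c1` gives 91%
compound 2 `Cc1ccc2ncc(S(=O)(=O)c3cc(Cl)cc(Cl)c3)c(N3CCC(C)CC3)c2c1` gives 75%
compound 3 `Cc1ccc2ncc(S(=O)(=O)c3ccc(F)c(Cl)c3)c(N3CCC(C)CC3)c2c1` gives 93%

In an assay on isolated protein for displacement of a labelled ligand from metabotropic glutamate receptor 5 (Homo sapiens), with a stated time of 60 min, tested at 1 uM (a higher number here means more inhibition at the concentration tested (going by the name of the read-out), a lower number less inhibition), compound 3 stands at the top of the three numbers, though only compound 2 lies beyond the scatter from it; the gap to compound 1 is within the scatter. Compound 4 `Cc1ccc2ncc(S(=O)(=O)c3cccc(Cl)c3)c(N3CCC(C)CC3)c2c1` differs from compound 3 by hydrogen in place of fluoro on an aromatic carbon. The step that bears on this carbon is a number 2 percentage points higher from compound 1 to compound 3 (within the scatter), where methyl and fluoro at the same place gave numbers within the scatter of each other. The loss of both chloro groups' partner in a number 16 percentage points lower from compound 1 to compound 2 (beyond the scatter) concerned another position and does not apply here. Compound 4 is therefore expected to change only slightly, with an estimated step of a number 7 percentage points lower from compound 3 to compound 4 (within the scatter), and is expected to give 86%, between 72% and 96%.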

Compound 4, a percentage reported as inhibition, at one concentration (the size of the read-out at that concentration, not a potency): 91%
The estimate for compound 4 lay 5 percentage points below the measured number; low and high end bracket the measured number.
By their numbers in this assay, from the lowest: compound 2; then compounds 1, 4 and 3 (each within the scatter of the next).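

Taking away the fluoro gives a number 2 percentage points lower from compound 3 to compound 4 (within the scatter) and taking away the methyl gives no change at the digits printed from compound 1 to compound 4 (within the scatter), so hydrogen, fluoro and methyl on this carbon, para to a large group, cannot be told apart by their numbers. Hydrogen in place of chloro at a different carbon of the ring gives a number 16 percentage points higher from compound 2 to compound 4 (beyond the scatter), which ties the lower number of compound 2 to its second chloro. Nothing measured here gives a reason for either result. Still open, as far as these compounds go, is whether an amine, a methoxy group or a carboxylic acid on this carbon would keep the number, and what replacing the remaining chloro with hydrogen would do.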